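The source may hold more compounds than are shown below. What is called first, only, known or untested is meant among the compounds shown, and "the series" means these compounds.

Compound 1 `N#Cc1ccc(N2CCN(C(=S)SCc3ccc(C(=O)Nc4ccccc4N)cc3)CC2)cc1`: 71.6%
Compound 2 `Nc1ccccc1NC(=O)c1ccc(CSC(=S)N(Cc2ccccc2)Cc2ccccc2)cc1`: 1%
Compound 3 `CN(Cc1ccncc1)C(=S)SCc1ccc(C(=O)Nc2ccccc2N)cc1`: 29.5%

Of the compounds shown here, three sharing a common core have been measured in a functional assay on HeLa cells (Homo sapiens) for antiproliferative activity, read by CCK-8 assay, with a stated time of 72 h, tested at 2 uM; on this read-out lower numbers stand for a weaker effect and higher numbers for a stronger effect at the one concentration tested. Among them compound 1 stands highest: compound 3 gives a number lower by a margin beyond the scatter, and compound 2 lies further below still, also beyond the scatter. No two of these compounds differ in a single place, so no step between measured compounds is available, and the standing of compound 1 rests on its own value alone.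

Compound 4 `Nc1ccccc1NC(=O)c1ccc(CSC(=S)N2CCN(c3cnccn3)CC2)cc1` has not yet been measured. It differs from compound 1 in one place: pyrazin-2-yl in place of 4-cyanophenyl on an amine nitrogen in a ring. The ring nitrogen that carries the large group keeps its place; only the group on it changes.

Among the compounds with values here, with no measured step to lean on, the expectation for compound 4 can only be an estimate. An aromatic ring on the ring nitrogen is retained in compound 4, and compound 1, which also carries one, gives 71.6%, the highest of the three readings. The expected step from compound 1 to compound 4 is a number 16.6 percentage points lower from compound 1 to compound 4 (beyond the scatter), a modest loss that may not exceed the scatter. Compound 4 is estimated to give 55% in this assay, within a range from 30% to 80%.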

Compound 4, a percentage reported as inhibition, at one concentration (the size of the read-out at that concentration, not a potency): 70.4%
Estimate against measurement, compound 4: 15.4 percentage points below; the range from low to high includes it.
By their numbers in this assay, from the lowest: compound 2; then compound 3; then compounds 4 and 1 (each within the scatter of the next).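

In this assay, within the data shown here, placing pyrazin-2-yl instead of 4-cyanophenyl on the amine nitrogen in the ring gives a number 1.2 percentage points lower from compound 1 to compound 4 (within the scatter), the first step that can be read at this position. The earlier compounds shown here could not show that the high reading of compound 1 survives a change of this group, yet compound 4, which has lost the nitrile and whose six-membered aromatic ring holds hetero atoms, cannot be told apart from compound 1 at the one concentration tested, so for this pair neither the nitrile nor a ring of carbon only is needed to keep the reading. Nothing measured on the two groups speaks to why they read alike.

Both readings come from a single concentration, so any difference in potency between compound 1 and compound 4 could still lie hidden beneath them. Going by these compounds, it also remains open whether an aromatic ring on this nitrogen is needed at all, a question that an acetyl group or a cyclohexyl ring in the same place would address, and whether a pyridin-2-yl ring would read like this pair.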